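Adding a Second Fluorine to a Weakly Active Amide

A few compounds are considered here, and "the series" means these few. Any claim that something is new, unique, unknown or untested is made for them only; others in the source may bear on it.

Compound 3 `O=C(Nc1ccc(Oc2ccnc3[nH]ccc23)c(F)c1)c1cc(-c2ccccc2)ccn1` was tested in a functional assay on MCF7 cells (Homo sapiens) for cytotoxicity, read by MTT assay, with a stated time of 72 h; on this read-out lower numbers stand for stronger inhibition and higher numbers for weaker inhibition. There compound 3 gives > 10000 nM, which is a limit of the assay rather than a measured number. Its nearest measured relative, compound 2 `O=C(Nc1ccc(Oc2ccnc3[nH]ccc23)cc1)c1cc(-c2ccccc2)ccn1`, lacks the fluoro on the ring that carries the amide nitrogen, and in this assay compound 2 gives 3750 nM. For the measured compounds named here, the only measured step, an at least 2.6-fold higher number from compound 2 to compound 3 (0.42 log units; beyond the scatter), thus moved toward weaker inhibition. Compound 1 `COc1ccc(-c2ccc(C(=O)Nc3ccc(Oc4ccnc5[nH]ccc45)cc3)nc2)cc1`, which arranges the same pieces differently, also reaches a limit: in this assay compound 1 gives > 10000 nM.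

Compound 4 `O=C(Nc1ccc(Oc2ccnc3[nH]ccc23)c(F)c1)c1cc(-c2ccc(F)cc2)ccn1` differs from compound 3 by fluoro in place of hydrogen on an aromatic carbon. Going by the values given here, no measured pair shows what a fluoro in this place does, and the one step that was measured concerned a fluoro on a different ring, so it gives only a general hint that adding fluorine here did not help. Since compound 3 already sits at the limit noted in the limit of > 10000 nM in this assay, at which 2 of the 3 values shown sit, compound 4 is expected to stay at or near that limit, and the estimated step that the limit leaves unreadable from compound 3 to compound 4 is expected to be small. Compound 4 is estimated at 15000 nM, with a range from 5000 nM to 50000 nM.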

Compound 4, half-maximal inhibitory concentration: 9520 nM
The estimate for compound 4 lay 1.6-fold (0.20 log units) above the measured number; the range from low to high includes it.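

Changing phenyl to 4-fluorophenyl tests a new place on the molecule, on the ring far from the fluoro examined in the earlier step. In this assay compound 4 gives 9520 nM, a measured number and not a limit, so a fluoro at this place at least leaves the compound on the readable side of the assay, even with the other fluoro still present. The step is an at least 1.0-fold lower number from compound 3 to compound 4 (0.02 log units; that floor lies within the scatter), and it can be read only as a floor because compound 3 has no number of its own, only a limit: the limit of > 10000 nM in this assay, at which 2 of the 4 values shown sit.

From the compounds shown here alone, the true size of this step therefore stays open, and so does what the same 4-fluorophenyl ring would do in compound 2, which lacks the other fluoro and has a measured number to compare against. For the compounds shown here, it also remains open whether another group at this place, such as a nitrile, a trifluoromethyl or an amine, would give a number that stands clearly apart from the one for compound 4.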